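Chloro for hydrogen on a second core in paw edema

The source may report more compounds than this note shows. Statements on the series, on what has been measured and on what is new or still open speak of the compounds shown alone.

Of the compounds shown here, three with a shared side chain have been tested in a functional assay on the whole organism (strain albino) for inhibition, with Rattus norvegicus as the target, read by paw edema, with stated times of 1 h and 3 h, at a dose of 100 mg/kg by the oral route; on this read-out lower numbers stand for a weaker effect and higher numbers for a stronger effect at the one dose given. Compound 1, with the structure `O=C(CSc1nc(-c2ccccc2)c(C(=O)O)c(=O)[nH]1)Nn1c(COc2ccc(Cl)cc2Cl)nc2ccccc2c1=O`, gives 64.9% in this assay. Compound 2, `O=C(CSc1nc(-c2ccc(Cl)cc2)c(C(=O)O)c(=O)[nH]1)Nn1c(COc2ccc(Cl)cc2Cl)nc2ccccc2c1=O`, differs from compound 1 by a single change, (chloro in place of hydrogen on an aromatic carbon), and compound 2 gives 61.4%. The step of a number 3.5 percentage points lower from compound 1 to compound 2 (within the scatter) is therefore small. Compound 3, `N#Cc1c(Nc2ccccc2)nc(SCC(=O)Nn2c(COc3ccc(Cl)cc3Cl)nc3ccccc3c2=O)nc1-c1ccccc1`, carries a different core; how the core of compound 3 differs from that of compound 1 is not broken down here. Compound 3 gives 78.1%, which stands highest of the three, beyond the scatter from both compound 1 and compound 2.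

Compound 4, `N#Cc1c(Nc2ccc(Cl)cc2)nc(SCC(=O)Nn2c(COc3ccc(Cl)cc3Cl)nc3ccccc3c2=O)nc1-c1ccccc1`, has not been measured. It differs from compound 3 by chloro in place of hydrogen on an aromatic carbon, the same change that was made from compound 1 to compound 2, at a place described in the same words: on an aromatic carbon of a six-membered aromatic ring of carbon only, para to a large group. Because the step of a number 3.5 percentage points lower from compound 1 to compound 2 (within the scatter) stayed within the scatter, the expected step of a number 3.1 percentage points lower from compound 3 to compound 4 (within the scatter) is likewise estimated to be small. Compound 4 is thus expected to give about 75% in this assay, with an estimated range from 65% to 85%.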

Compound 4, a percentage reported as inhibition, in the whole organism at one dose (the size of the read-out at that dose, not a potency): 59.7%
Estimate against measurement, compound 4: 15.3 percentage points above; measured number below the stated range.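

In this assay, chloro in place of hydrogen gave a number 18.4 percentage points lower from compound 3 to compound 4 (beyond the scatter), so the small step seen on the core of compound 1 did not carry over to the core of compound 3. Set side by side, the two steps differ, and in this series the size of this change read on one core cannot be assumed on the other: the same change on two cores in this assay, a number 3.5 percentage points lower (within the scatter) from compound 1 to compound 2 and a number 18.4 percentage points lower (beyond the scatter) from compound 3 to compound 4, 14.9 percentage points apart, beyond the scatter of two such steps This does not show why the steps differ, as the evidence rests on a single pair for each core at one dose, and the two pairs also differ in where the change falls, phenyl to 4-chlorophenyl in one and anilino to (4-chlorophenyl)amino in the other, so the core and the group carrying the chloro cannot be told apart.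

The compounds shown leave open whether chloro on the phenyl group of the core of compound 3, rather than on its anilino group, would give a step closer to the one from the core of compound 1. They also leave open how a bromo, methyl or methoxy group in place of the chloro would read on either core.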